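This account rests on a few compounds, and the source may have more. Where it says the series, first, only, none or still open, it means among the compounds named here.

In an ADME assay on MRC5 cells (Homo sapiens) for cytotoxicity, read by MTT assay, with a stated time of 72 h (a lower number here means that less compound is tolerated, a higher number that more compound is tolerated), compound 1 `CCCCCCCCCCCCCCCCCCOP(=O)(O)OC[C@H]1O[C@@H](n2ccc3c(-c4ccco4)ncnc32)[C@H](O)[C@@H]1O`, which carries furan-2-yl, gives 45300 nM. Compound 2 `CCCCCCCCCCCCCCCCCCOP(=O)(O)OC[C@H]1O[C@@H](n2ccc3c(-c4ccoc4)ncnc32)[C@H](O)[C@@H]1O`, which carries furan-3-yl, gives > 50000 nM, and this is a limit of the assay, not a number. The step of an at least 1.1-fold higher number from compound 1 to compound 2 (0.04 log units; that floor lies within the scatter) is the only measured one, and it does not go beyond the scatter. Compound 3 `CCCCCCCCCCCCCCCCCCOP(=O)(O)OC[C@H]1O[C@@H](n2ccc3c(-c4cccs4)ncnc32)[C@H](O)[C@@H]1O`, which carries thiophen-2-yl, has no number to start from, as its result is "not determined" (no result reported). Compound 4 `CCCCCCCCCCCCCCCCCCOP(=O)(O)OC[C@H]1O[C@@H](n2ccc3c(-c4cc5ccccc5o4)ncnc32)[C@H](O)[C@@H]1O` replaces that group with 1-benzofuran-2-yl on an aromatic carbon (1-benzofuran-2-yl in place of thiophen-2-yl on an aromatic carbon). For the measured compounds named here, no measured step adds a ring in this way, so the one furan swap is only a loose guide, and no step from compound 3 can be sized. In this assay, the expectation therefore stays close to the value of compound 1, which is 45300 nM, and the data give no firm direction. Compound 4 is estimated at 35000 nM, with an expected range of 12000 nM to 50000 nM.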

Compound 4, half-maximal cytotoxic concentration: > 50000 nM
Compound 4: only a limit was reported (the forecaster's own chance of this, stated with the estimate: 35%); middle value at least 1.4-fold (0.15 log units) away from the limit.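

In this assay, compound 4 gives > 50000 nM, which is a limit and not a number. It shows that this aromatic carbon of the shared core takes 1-benzofuran-2-yl, with its added six-membered aromatic ring of carbon only, without a drop in the reading: the change gives an at least 1.1-fold higher number from compound 1 to compound 4 (0.04 log units; that floor lies within the scatter). The step from compound 2 to compound 4 cannot be read because both compounds stand at the same limit: the limit of > 50000 nM in this assay, at which 2 of the 4 values shown sit.

Compound 3 has no reported result, so the exchange of thiophen-2-yl for 1-benzofuran-2-yl itself remains unsized. Where the reading in this assay would fall with an amine or a carboxylic acid at this position, or with a shorter chain on the phosphate, stays open.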